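From Methoxy to Hydroxy: One Small Change

A few compounds are considered here, and "the series" means these few. Any claim that something is new, unique, unknown or untested is made for them only; others in the source may bear on it.

In an ADME assay on microsomes from liver (Mus musculus) for metabolic stability, with a stated time of 10 min (a higher number here means that more of the compound is left, a lower number that less of the compound is left), compound 3 `COC12CCC(c3nnc4c(Oc5cccc(Cl)c5C)cccn34)(CC1)CC2` gives 70%, the higher of the two numbers available. Compound 1 `Cc1c(Cl)cccc1Oc1cccn2c(C34CCC(CC3)C4)nnc12` gives 57%, a gap beyond the usual scatter, while compound 2 `Cc1c(Cl)cccc1Oc1cccn2c(C34CCC(N)(CC3)CC4)nnc12` has the entry "not determined" (no result reported). Compound 4 `Cc1c(Cl)cccc1Oc1cccn2c(C34CCC(O)(CC3)CC4)nnc12` differs from compound 3 in one place: hydrogen in place of methyl on an oxygen on a saturated carbon. This puts hydrogen in place of methyl on an oxygen on a saturated carbon, turning methoxy to hydroxy. Within the data shown here, no measured pair shows this change, so any forecast in this assay is a judgement rather than a trend. A small upward move is expected, possibly within the scatter, and the estimated step is a number 8 percentage points higher from compound 3 to compound 4 (within the scatter). Compound 4 is estimated at 78%, with an expected range from 60% to 93%.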

Compound 4, percent of the compound remaining: 96%
Compound 4: middle estimate off by 18 percentage points, on the low side, and the stated range ends below it.
By their numbers in this assay, from the lowest: compound 1; then compound 3; then compound 4.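

Taking the methyl off the oxygen on a saturated carbon gives a number 26 percentage points higher from compound 3 to compound 4 (beyond the scatter) in this assay and shows that this one small change can move the read-out by more than the scatter. Exchanging the whole group on the aromatic carbon gives a number 39 percentage points higher from compound 1 to compound 4 (beyond the scatter) and is a larger change in structure as well as in number. The data shown offer no explanation for either step.

On these data alone, whether a longer chain on that oxygen, such as ethoxy, would stay closer to methoxy or to hydroxy remains open, as does the effect of a carboxylic acid at this place. Compound 2 has no number, so steps to it cannot be read.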